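The compounds below may be only part of what the source reports. "The series", "measured", "known", "first", "only" and "open" are said of these compounds alone.

Measured in an ADME assay on HeLa cells (Homo sapiens) for cytotoxicity, read by MTT assay, with a stated time of 2 days; a lower number here means that less compound is tolerated, a higher number that more compound is tolerated:
- Compound 1 `CCOC(=O)c1sc2cc(Oc3ccnc(C(=O)NC)c3)ccc2c1C` gives > 100000 nM (a limit).
- Compound 2 `CNC(=O)c1cc(Oc2ccc3c(C)c(C(=O)OC)sc3c2)ccn1` gives 15700 nM (a number).
- Compound 3 `CNC(=O)c1cc(Oc2ccc3c(C)c(C(=O)O)sc3c2)ccn1` gives > 100000 nM (a limit).

Compound 1 offers only a limit in this assay, not a number. It stands at the limit of > 100000 nM in this assay, at which 2 of the 3 values shown sit, so any readable step from it would be towards a lower number.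

Compound 4 `CCOC(=O)c1sc2cc(Oc3ccnc(C(=O)NC)c3)ccc2c1N` carries amino in place of methyl on an aromatic carbon, next to the ring atom that bears an ethoxycarbonyl group. Among the compounds with values here, no measured step touches this carbon. All three change the group on the oxygen next to the carbonyl group, so they are only a loose guide. They show an at least 6.3-fold lower number from compound 1 to compound 2 (0.80 log units; beyond the scatter) and an at least 6.3-fold higher number from compound 2 to compound 3 (0.80 log units; beyond the scatter), while the third is a step that the two limits leave unreadable from compound 1 to compound 3. Since the first of these shows that a single small change can bring a readable value, a modest move to a lower number is expected, though compound 4 may well stay at the limit.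

Compound 4 is expected at 50000 nM, within an estimated range of 15000 nM to 100000 nM. This estimate means an expected at least 2.0-fold lower number from compound 1 to compound 4 (0.30 log units; that floor lies within the scatter).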

Compound 4, half-maximal cytotoxic concentration: 450 nM
Compound 4: middle estimate off by 110-fold (2.05 log units), on the high side, and the stated range ends above it.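

In this assay, amino in place of methyl on this aromatic carbon gives an at least 220-fold lower number from compound 1 to compound 4 (2.34 log units; beyond the scatter). Earlier steps changed only the group on the oxygen next to the carbonyl group, whereas this result shows that a change of a single heavy atom at this carbon of the five-membered ring can also move the value, and that the step is large. Compound 1 gives only a limit, so the true size of the step cannot be read beyond that floor: the limit of > 100000 nM in this assay, at which 2 of the 4 values shown sit.

The compounds shown leave open whether this step belongs to amino itself or would also appear with a hydroxyl, an acetamide or a dimethylamino group on this carbon. They also leave open whether amino would act the same way with a methyl ester or a carboxylic acid in place of the ethoxycarbonyl group.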